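Pyridin-3-yl to 4-hydroxyphenyl: expected step in the series

The compounds below may be only part of what the source reports. "The series", "measured", "known", "first", "only" and "open" are said of these compounds alone.

Three compounds sharing the core of compound 1 `Oc1ccc(-c2cc(-c3ccccc3)cc(-c3ccsc3)n2)cc1` have been measured in a functional assay on DU-145 cells (Homo sapiens) for cytotoxicity, read by ELISA, with a stated time of 2 days; a lower number here means a stronger inhibitor, a higher number a weaker inhibitor. Compound 1 gives 8500 nM. Compound 2 `Oc1ccc(-c2cc(-c3ccccc3)cc(-c3ccco3)n2)cc1` gives 3200 nM. Compound 3 `Oc1ccc(-c2cc(-c3ccccc3)cc(-c3cccnc3)n2)cc1` gives 8400 nM. Compound 3 stands level with the thiophen-3-yl analogue, with a 1.0-fold lower number from compound 1 to compound 3 (0.01 log units; within the scatter). The furan-2-yl analogue stands apart from both, with a 2.7-fold lower number from compound 1 to compound 2 (0.42 log units; beyond the scatter) and a 2.6-fold higher number from compound 2 to compound 3 (0.42 log units; beyond the scatter).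

Compound 4 `Oc1ccc(-c2cc(-c3ccccc3)cc(-c3ccc(O)cc3)n2)cc1` carries 4-hydroxyphenyl in place of pyridin-3-yl on an aromatic carbon, next to the ring nitrogen: 4-hydroxyphenyl in place of pyridin-3-yl on an aromatic carbon. Among the measured compounds shown here, no measured step introduces this group, so the evidence is indirect. All three measured steps are exchanges at this same place, and the largest of them is only modest, at a 2.6-fold higher number from compound 2 to compound 3 (0.42 log units; beyond the scatter). Nothing in them gives a direction for the new group. In this assay, no step beyond the scatter is therefore expected, and the expected result is a 1.2-fold lower number from compound 3 to compound 4 (0.08 log units; within the scatter). For compound 4 the estimated value is 7000 nM, with an expected range of 2500 nM to 20000 nM.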

Compound 4, half-maximal inhibitory concentration: 22000 nM
The estimate for compound 4 lay 3.1-fold (0.50 log units) below the measured number; measured number above the stated range.
By their numbers in this assay, from the lowest: compound 2; then compounds 3 and 1 (each within the scatter of the next); then compound 4.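

In this assay, this place, on an aromatic carbon next to the ring nitrogen, is not indifferent to the group it carries: 4-hydroxyphenyl gives the weakest compound of the four, with a 2.6-fold higher number from compound 3 to compound 4 (0.42 log units; beyond the scatter), a 2.6-fold higher number from compound 1 to compound 4 (0.41 log units; beyond the scatter) and a 6.9-fold higher number from compound 2 to compound 4 (0.84 log units; beyond the scatter). The last of these steps exceeds the largest exchange seen before, a 2.6-fold higher number from compound 2 to compound 3 (0.42 log units; beyond the scatter), so the measured span at this place is wider than the first three compounds showed, and the new group moves the number up rather than leaving it level with pyridin-3-yl and thiophen-3-yl. No measurement at hand accounts for this rise.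

Still open, from the compounds shown here alone, is whether the higher number goes with the hydroxyl or with the carbon-only six-membered ring, a question that an unsubstituted phenyl or a 4-methoxyphenyl at this place would help to separate. Also open, going by these compounds, is whether the lower number of compound 2 is particular to furan-2-yl or extends to other five-membered rings such as furan-3-yl or thiophen-2-yl.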